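The compounds below may be only part of what the source reports. "The series", "measured", "known", "first", "only" and "open" are said of these compounds alone.

For the measured compounds named here, compound 1 `N#Cc1ccc2c(Oc3ccc(F)cc3OCCn3ccc(=O)[nH]c3=O)cc(Cl)cc2c1` is the only one of the three compounds that returns a number in an ADME assay on MT2 cells (Homo sapiens) for cytotoxicity, read by MTT assay; on this read-out higher numbers stand for lower toxicity in this test and lower numbers for higher toxicity in this test: compound 1 gives 16000 nM. Compound 2 `N#Cc1cc2c(Oc3ccccc3OCCn3ccc(=O)[nH]c3=O)cccn2c1` reaches only a limit of the assay, > 100000 nM. Compound 3 `N#Cc1ccc2c(Oc3ccc(F)cc3OCCn3ccc(=O)[nH]c3=O)cc(F)cc2c1` likewise reaches only a limit, > 100000 nM. Going by the values given here, the single measured step, an at least 6.2-fold higher number from compound 1 to compound 3 (0.79 log units; beyond the scatter), concerns the other ring and the chloro, and it ends at the limit of > 100000 nM in this assay, at which 2 of the 3 values shown sit. Compound 4 `N#Cc1ccc2c(Oc3ccccc3OCCn3ccc(=O)[nH]c3=O)cc(Cl)cc2c1` differs from compound 1 in one place: hydrogen in place of fluoro on an aromatic carbon. Among the compounds with values here, no measured step covers this kind of change, so for compound 4 nothing beyond the scatter is expected in this assay, in either direction. Compound 4 is therefore expected to give about 20000 nM, between 6000 nM and 100000 nM, which would mean a 1.3-fold higher number from compound 1 to compound 4 (0.10 log units; within the scatter).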

Compound 4, half-maximal cytotoxic concentration: 24000 nM
Beside the measured number, compound 4's estimate is 1.2-fold (0.08 log units) below it; measured number inside the range.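

In this assay, hydrogen in place of fluoro on this aromatic carbon, meta to a large group and para to a large group, gives a 1.5-fold higher number from compound 1 to compound 4 (0.18 log units; within the scatter). Losing the fluoro at this place therefore leaves the number indistinguishable from that of compound 1, whereas the change from chloro to fluoro gave an at least 6.2-fold higher number from compound 1 to compound 3 (0.79 log units; beyond the scatter). Nothing shown here gives a cause for either result. Going by these compounds, whether an amine or a methoxy group at this place would move the number stays open. So does whether the chloro to fluoro step would hold without the fluoro studied here.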